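Indanylamine replaces thienylmethyl amine on the piperidine carbon

The compounds below may be only part of what the source reports. "The series", "measured", "known", "first", "only" and "open" are said of these compounds alone.

The measured compounds:
compound 1 `C[C@@H](NCC1CCN(CCCc2c[nH]c3ccc(-n4cnnc4)cc23)CC1)c1ccccc1`, 14 nM
compound 2 `CC(C)=CCCN(C)C1CCN(CCCc2c[nH]c3ccc(-n4cnnc4)cc23)CC1`, 24 nM
compound 3 `CN(Cc1cccs1)C1CCN(CCCc2c[nH]c3ccc(-n4cnnc4)cc23)CC1`, 140 nM

In an assay on CHO cells for displacement of a labelled ligand from 5-hydroxytryptamine receptor 1B (Homo sapiens) (a higher number here means a weaker inhibitor, a lower number a stronger inhibitor), compound 3 gives the highest of the three numbers; its neighbours lie well apart from it, shown by a 10-fold higher number from compound 1 to compound 3 (1.00 log units; beyond the scatter) and a 5.8-fold higher number from compound 2 to compound 3 (0.77 log units; beyond the scatter). Compound 4 `c1ccc2c(c1)CCC2NC1CCN(CCCc2c[nH]c3ccc(-n4cnnc4)cc23)CC1` differs from compound 3 by (2,3-dihydro-1H-inden-1-yl)amino in place of methyl((thiophen-2-yl)methyl)amino on a saturated ring carbon. Both of the steps that end at compound 3 bear on this change: each replaced a group carrying no hydrogen-bond donor on the nitrogen of the aminomethyl or amino unit for one that does, or a ((1-phenylethyl)amino)methyl group for the methyl((thiophen-2-yl)methyl)amino group, and each raised the number by a modest amount. The change to compound 4 moves back toward a group with 1 hydrogen-bond donor and a six-membered aromatic ring of carbon only, as in compound 1, so a lower number is expected in this assay, roughly a 4.7-fold lower number from compound 3 to compound 4 (0.67 log units; beyond the scatter). Compound 4 is therefore estimated at 30 nM, within 10 nM to 90 nM.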

Compound 4, half-maximal inhibitory concentration: 280 nM
Compound 4: the middle estimate sits 9.3-fold (0.97 log units) below what was measured; measured number above the stated range.
By their numbers in this assay, from the lowest: compounds 1 and 2 (each within the scatter of the next); then compounds 3 and 4 (each within the scatter of the next).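

In this assay, the replacement at this saturated ring carbon shows a 2.0-fold higher number from compound 3 to compound 4 (0.30 log units; within the scatter), so (2,3-dihydro-1H-inden-1-yl)amino and methyl((thiophen-2-yl)methyl)amino cannot be told apart here, although only the entering group has a hydrogen-bond donor and a six-membered aromatic ring of carbon only. Those two features together did not bring compound 4 close to compound 1, as a 20-fold higher number from compound 1 to compound 4 (1.30 log units; beyond the scatter) shows, while compound 2 has neither and still stands well apart, with a 12-fold higher number from compound 2 to compound 4 (1.07 log units; beyond the scatter). Nothing available explains these differences.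

The compounds shown leave open whether the gap to compound 1 follows from the closed five-membered ring of the entering group or from the aminomethyl link present in compound 1. A benzylamino group or a (2,3-dihydro-1H-inden-1-yl)aminomethyl group on the same ring carbon would bear on that question.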